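Naphthalen-1-yl to 4-chlorophenyl: expectation for compound 3

The compounds below may be only part of what the source reports. "The series", "measured", "known", "first", "only" and "open" are said of these compounds alone.

The series is followed in a functional assay on aorta (strain Wistar) for inhibition, with Thoracic aorta (Rattus norvegicus) as the target; a higher number here means a weaker inhibitor, a lower number a stronger inhibitor. Compound 1, `COc1nc(-c2cc3ccccc3o2)cc(-c2ccccc2)c1C#N`, gives 232000 nM in this assay. Compound 2, `CCOc1nc(-c2cc3ccccc3o2)cc(-c2cccc3ccccc23)c1C#N`, gives 344000 nM in this assay. Within the data shown here, of the two numbers known so far, the number for compound 2 lies within the usual scatter of the number for compound 1, so the two compounds cannot be told apart on these data. Among the measured compounds shown here, no step between measured compounds that differ in only one place has been worked out.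

The next compound, compound 3, is `CCOc1nc(-c2cc3ccccc3o2)cc(-c2ccc(Cl)cc2)c1C#N`. Relative to compound 2 the change is 4-chlorophenyl in place of naphthalen-1-yl on an aromatic carbon. For the measured compounds named here, nothing among the measured compounds bears on this exchange directly, and the two known numbers for compound 1 and compound 2 sit close together. The step from compound 2 to compound 3 in this assay is therefore expected to be small, a 1.3-fold lower number from compound 2 to compound 3 (0.12 log units; within the scatter), with no direction beyond the scatter. Compound 3 is estimated at 260000 nM in this assay, in the range 110000 nM to 620000 nM.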

Compound 3, half-maximal inhibitory concentration: 221000 nM
Estimate against measurement, compound 3: 1.2-fold (0.07 log units) above, and the stated range covers the measured number.
By their numbers in this assay, from the lowest: compounds 3, 1 and 2 (each within the scatter of the next).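

At the aromatic carbon opposite the ring nitrogen, ortho to a cyano group, the series now has its first step that differs in one place only: in this assay, 4-chlorophenyl in place of naphthalen-1-yl gives a 1.6-fold lower number from compound 2 to compound 3 (0.19 log units; within the scatter) and so no separation between the two compounds. With the ethoxy group, the cyano group and the 1-benzofuran-2-yl group held constant, this position accepts the exchange of two six-membered aromatic rings of carbon for one ring bearing chlorine without a reading beyond the scatter, a statement that rests on this single pair. No measurement offered here explains this outcome or says what the two groups have in common in this assay.

As far as these compounds go, it remains open whether any group at this position moves the number beyond the scatter, for instance an amine or a carboxylic acid on the phenyl ring in place of chlorine. The ethoxy group also remains unresolved as a single change, since compound 1 differs from compound 2 in two places, and a longer chain at that oxygen would test that site on its own.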